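Thiophene in Place of Dichlorophenyl on Compound 1

The source may report more compounds than this note shows. Statements on the series, on what has been measured and on what is new or still open speak of the compounds shown alone.

Compound 1 `COC(=O)c1cc(-c2csc(N/N=C/c3ccc(Cl)cc3Cl)n2)ccc1OCc1ccccc1` gives 19.2% in a functional assay, read by spectrophotometry, with a stated time of 15 min, tested at 20 ug/mL; a higher number here means a stronger effect of the compound at the concentration tested, a lower number a weaker effect. Compound 2 `Clc1ccc(/C=N/Nc2nc(-c3ccccc3)cs2)c(Cl)c1` gives 76.6%, so compound 1 stands lowest of the two measured numbers, well beyond the scatter below compound 2. Compound 3 `COC(=O)c1cc(-c2csc(N/N=C/c3cccs3)n2)ccc1OCc1ccccc1` has not been measured; it differs from compound 1 by thiophen-2-yl in place of 2,4-dichlorophenyl on a carbon with a double bond to nitrogen. Within the data shown here, no measured pair shows this exchange, so its effect is unknown. The expected step of a number 2.8 percentage points higher from compound 1 to compound 3 (within the scatter) is small, in no direction beyond the scatter. Compound 3 is therefore estimated at 22%, within a range from 5% to 45%.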

Compound 3, a percentage reported as inhibition, at one concentration (the size of the read-out at that concentration, not a potency): 94.3%
The estimate for compound 3 lay 72.3 percentage points below the measured number; measured number above the stated range.
By their numbers in this assay, from the lowest: compound 1; then compound 2; then compound 3.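

In this assay, the group on the carbon with a double bond to nitrogen turns out to matter strongly: thiophen-2-yl in place of 2,4-dichlorophenyl gives a number 75.1 percentage points higher from compound 1 to compound 3 (beyond the scatter), with the rest of the molecule unchanged. The earlier compounds shown here could not show this, since compound 1 and compound 2 differ in more than one place. No measurement here accounts for the size of this step.

As far as these compounds go, whether a furan-2-yl group in this place would match thiophen-2-yl remains open. So does whether the same exchange would give a similar step on the core of compound 2.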